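Removing the Iodine: From Compound 3 to Compound 4

The source may hold more compounds than are shown below. What is called first, only, known or untested is meant among the compounds shown, and "the series" means these compounds.

Compound 3 `COc1cc(C(=O)c2sc(-c3ccc(I)cc3)cc2N)cc(OC)c1OC` gives 400 nM in a functional assay on L1210 cells (Mus musculus) for antiproliferative activity (on this read-out lower numbers stand for stronger inhibition and higher numbers for weaker inhibition), the highest of the three numbers measured, set against compound 1 `COc1cc(C(=O)c2sc(-c3cccs3)cc2N)cc(OC)c1OC` with 9.8 nM and compound 2 `COc1cc(C(=O)c2sc(-c3cccc([N+](=O)[O-])c3)cc2N)cc(OC)c1OC` with 11 nM. The step of a 41-fold higher number from compound 1 to compound 3 (1.61 log units; beyond the scatter) and the step of a 36-fold higher number from compound 2 to compound 3 (1.56 log units; beyond the scatter) both mark the 4-iodophenyl compound as the weakest of the three. Compound 4 `COc1cc(C(=O)c2sc(-c3ccccc3)cc2N)cc(OC)c1OC` differs from compound 3 by hydrogen in place of iodo on an aromatic carbon. For the measured compounds named here, no measured step shows exactly this change, so the expectation can rest only on the fact that the two compounds without the 4-iodophenyl group, compound 1 and compound 2, sit far lower. If the phenyl compound behaves more like those two than like compound 3, a return toward lower numbers is the reasonable expectation, though its full size is uncertain. The estimated step is therefore a 16-fold lower number from compound 3 to compound 4 (1.20 log units; beyond the scatter), downward and beyond the scatter. For compound 4 the expected value in this assay is 25 nM, with a likely range from 6 nM to 120 nM.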

Compound 4, half-maximal inhibitory concentration: 11 nM
Compound 4: the middle estimate sits 2.3-fold (0.36 log units) above what was measured; the measured number falls inside the stated range.
By their numbers in this assay, from the lowest: compounds 1, 2 and 4 (each within the scatter of the next); then compound 3.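

In this assay, the iodo group on this aromatic carbon turns out to account for the whole gap between compound 3 and the others, since hydrogen in its place gives a large step (a 36-fold lower number from compound 3 to compound 4 (1.56 log units; beyond the scatter)). The plain phenyl ring also stands level with the two other aryl groups (no change at the digits printed from compound 2 to compound 4 (within the scatter); a 1.1-fold higher number from compound 1 to compound 4 (0.05 log units; within the scatter)), so on this read-out the 3-nitrophenyl and thiophen-2-yl groups show no difference from phenyl. Nothing available bears on why the iodo group has this effect.

Iodo and hydrogen are the only two groups shown at this place on the phenyl ring, so it stays open whether the large step belongs to iodo alone. Fluoro, chloro, methoxy or an amine on the same carbon could fall on either side.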